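Vinyl to 2-methylprop-1-en-1-yl on the amide of compound 3

The source may report more compounds than this note shows. Statements on the series, on what has been measured and on what is new or still open speak of the compounds shown alone.

Compound 3 `C=CC(=O)Nc1cccc(Oc2nc(Nc3cccc(C#N)c3)nc3ccsc23)c1` gives 3790 nM in a functional assay on A-431 cells (Homo sapiens) for inhibition, read by MTT assay, with a stated time of 72 h (a higher number here means a weaker inhibitor, a lower number a stronger inhibitor), the lowest of the two numbers shown. Compound 1 `COc1cccc(Nc2nc(Oc3cccc(NC(=O)C=C(C)C)c3)c3sccc3n2)c1` gives 25800 nM. Compound 2 `COc1ccc(Nc2nc(Oc3cccc(NC(=O)C=C(C)C)c3)c3sccc3n2)cn1` gives only a limit, > 50000 nM; one of the three values shown sits at the limit of > 50000 nM in this assay, at which 1 of the 3 values shown sits. For the measured compounds named here, the one measured step, an at least 1.9-fold higher number from compound 1 to compound 2 (0.28 log units; that floor lies within the scatter), concerns the aromatic amine and not the amide. Compound 4 `CC(C)=CC(=O)Nc1cccc(Oc2nc(Nc3cccc(C#N)c3)nc3ccsc23)c1` differs from compound 3 by 2-methylprop-1-en-1-yl in place of vinyl on a carbonyl carbon. Going by the values given here, no measured pair isolates this change; compounds 1 and 2, which carry the 2-methylprop-1-en-1-yl amide, show weaker numbers than compound 3 but also differ in the aromatic amine. Compound 4 is expected to be weaker, a step of a 4.0-fold higher number from compound 3 to compound 4 (0.60 log units; beyond the scatter), with an estimated 15000 nM in this assay, between 4000 nM and 50000 nM.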

Compound 4, half-maximal inhibitory concentration: 28300 nM
Compound 4: middle estimate off by 1.9-fold (0.28 log units), on the low side, within the range that was stated.
By their numbers in this assay, from the lowest: compound 3; then compounds 1 and 4 (each within the scatter of the next). At a limit, above all of these: compound 2.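

For the compounds shown here, with the core and the 3-cyanophenyl group held fixed, the amide change alone gives a 7.5-fold higher number from compound 3 to compound 4 (0.87 log units; beyond the scatter), the first direct reading of 2-methylprop-1-en-1-yl in place of vinyl on this carbonyl carbon. With that larger amide held fixed, cyano in place of methoxy on the aromatic ring gives no step beyond the scatter: a 1.1-fold higher number from compound 1 to compound 4 (0.04 log units; within the scatter). The remaining comparison, an at least 1.7-fold lower number from compound 2 to compound 4 (0.24 log units; that floor lies within the scatter), gives only a floor, read against a limit: the limit of > 50000 nM in this assay, at which 1 of the 4 values shown sits.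

As far as these compounds go, only compound 3 carries vinyl, and whether this step holds with a methoxy-bearing aromatic amine stays open. Also open, from the compounds shown here alone, is how an ethyl group or a dimethylamino-bearing chain would read on the same carbonyl carbon.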